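A few compounds are considered here, and "the series" means these few. Any claim that something is new, unique, unknown or untested is made for them only; others in the source may bear on it.

Compound 1, `CC[C@H](C)C(=O)N1CCC(NC(=O)Nc2ccc(OC(F)(F)F)c(OC(F)(F)F)c2)CC1`: 5.5 ug/mL
Compound 2, `O=C(Nc1ccc(C(F)(F)F)cc1)NC1CCN(C(=O)C2CCOC2)CC1`: 9.6 ug/mL
Compound 3, `CCC(=O)N1CCC(NC(=O)Nc2ccc(OC(F)(F)F)c(F)c2)CC1`: 11 ug/mL

Three compounds sharing a core have been run in a physicochemical assay for solubility, read by mass spectrometry, in phosphate buffer, with a stated time of 24 h, at pH 7.4; a lower number here means a less soluble compound, a higher number a more soluble compound. Compound 1 stands at the low end of this set, giving 5.5 ug/mL, while compound 2 gives 9.6 ug/mL and compound 3 gives 11 ug/mL. The gap from compound 1 to either of the other two lies within the usual scatter of this assay, so the three cannot be told apart on these numbers, and no ordering among them should be read into the values.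

The next compound, compound 4, `CC[C@H](C)C(=O)N1CCC(NC(=O)Nc2ccc(OC(F)(F)F)c(Br)c2)CC1`, differs from compound 1 in one place: bromo in place of trifluoromethoxy on an aromatic carbon. Among the compounds with values here, no measured pair shows this exchange of bromo for trifluoromethoxy, so there is no step among the three measured compounds on which to base the size of the change. The available numbers sit close together, and nothing in them points to a movement beyond the scatter in either direction.

Compound 4 is therefore expected to give about 6 ug/mL in this assay, with a range from 2.5 ug/mL to 15 ug/mL. The step of a 1.1-fold higher number from compound 1 to compound 4 (0.04 log units; within the scatter) is estimated to be small, within the scatter, with no preferred direction.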

Compound 4, solubility: 0.58 ug/mL
Beside the measured number, compound 4's estimate is 10-fold (1.01 log units) above it, outside the stated range (below it).
By their numbers in this assay, from the lowest: compound 4; then compounds 1, 2 and 3 (each within the scatter of the next).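

In this assay, within the data shown here, bromo in place of trifluoromethoxy on this aromatic carbon, ortho to a trifluoromethoxy group, gives a 9.5-fold lower number from compound 1 to compound 4 (0.98 log units; beyond the scatter) and provides the first single-place step in the set. This shows that one exchange at this carbon can carry the read-out beyond the scatter, something the three earlier compounds could not show, as their numbers lay within the scatter of one another and no two of them differed in only one place. Nothing available accounts for the size of this step, and a single pair cannot say whether it comes from the arrival of bromo or the departure of trifluoromethoxy.

On these data alone, it remains open how other groups would fare on this same aromatic carbon, and a chloro group, a methoxy group or an amine there would show whether bromo stands alone or marks a wider trend. As far as these compounds go, it is equally open whether the same exchange would give a step of similar size on a compound with a different amide on the shared core, as this one pair speaks for compound 1 and compound 4 only.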